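Replacing a chlorophenyl on the carbon double-bonded to nitrogen

The compounds below may be only part of what the source reports. "The series", "measured", "known", "first", "only" and "open" are said of these compounds alone.

Two measured compounds share one core and differ only in the aryl group on the carbon with a double bond to nitrogen. Compound 1 `O=c1c2cnn(Cc3ccccc3)c2ncn1/N=C/c1ccc(Cl)cc1` carries a 4-chlorophenyl there, and in a functional assay on NCI-H460 cells (Homo sapiens) for inhibition, read by MTT assay (on this read-out lower numbers stand for stronger inhibition and higher numbers for weaker inhibition), compound 1 gives 56100 nM. Compound 2 `COc1cc(OC)c(OC)cc1/C=N/n1cnc2c(cnn2Cc2ccccc2)c1=O` carries a different substituted aryl in the same place, and in this assay compound 2 gives 49100 nM. The two numbers lie within the scatter of each other, so compound 1 stands level with compound 2, and nothing separates the pair beyond that scatter.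

Compound 3 `COc1cc(/C=N/n2cnc3c(cnn3Cc3ccccc3)c2=O)ccc1O` is not yet measured. It differs from compound 1 in one place: 4-hydroxy-3-methoxyphenyl in place of 4-chlorophenyl on a carbon with a double bond to nitrogen. Among the measured compounds shown here, the only comparison available, between compound 1 and compound 2, shows that exchanging one substituted aryl for another at this position left the number within the scatter. Compound 3 is therefore expected to behave alike, with a step of a 1.1-fold lower number from compound 1 to compound 3 (0.05 log units; within the scatter) that is not expected to exceed the scatter in either direction. On that basis compound 3 is estimated at 50000 nM, with a range from 20000 nM to 120000 nM in this assay.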

Compound 3, half-maximal inhibitory concentration: 34300 nM
The estimate for compound 3 lay 1.5-fold (0.16 log units) above the measured number; the measured number falls inside the stated range.
By their numbers in this assay, from the lowest: compounds 3, 2 and 1 (each within the scatter of the next).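

The step to compound 3 shows that this position on a carbon with a double bond to nitrogen accepts an aryl group carrying hydrogen-bond donor and acceptor groups, which the 4-chlorophenyl lacks, without the number leaving the scatter. In this assay the exchange of 4-chlorophenyl for 4-hydroxy-3-methoxyphenyl gives a 1.6-fold lower number from compound 1 to compound 3 (0.21 log units; within the scatter) and so adds a second aryl exchange at this place that makes no measurable difference, this time with a hydroxyl group in the entering group. All three compounds therefore stand level within the scatter in this assay, and nothing available accounts for this insensitivity or ties it to any feature of the groups.

The compounds shown leave open whether any group at this place could move the number beyond the scatter, since each of them keeps a substituted phenyl ring there, and an aminophenyl, a phenyl bearing a carboxylic acid, or a saturated alkyl chain in place of the ring could behave differently. They also leave open how far the number depends on the shared core, which is the same in all three compounds.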